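Configuration step from compound 2 to compound 3

The source may report more compounds than this note shows. Statements on the series, on what has been measured and on what is new or still open speak of the compounds shown alone.

In a functional assay on KB cells (Homo sapiens) for cytotoxicity, read by colorimetric assay and neutral red uptake, with a stated time of 72 h (a higher number here means a weaker inhibitor, a lower number a stronger inhibitor), compound 1 `CO[C@@H](C(=O)N[C@H]1CCCCNC1=O)[C@H](O)[C@@H](O)[C@H](O)/C=C/C(C)(C)C` gives 21000 nM and compound 2 `CO[C@@H](C(=O)N[C@H]1CC[C@H](O)CNC1=O)[C@H](O)[C@@H](O)[C@H](O)/C=C/C(C)(C)C` gives 19800 nM so the two stand level. Going by the values given here, compound 3 `CO[C@@H](C(=O)N[C@@H]1CC[C@@H](O)CNC1=O)[C@H](O)[C@@H](O)[C@H](O)/C=C/C(C)(C)C` relates to compound 2 thus: the two compounds have the same atoms and bonds and differ only in configuration as drawn: 2 of 7 stereo elements differ; a stereocentre at a saturated ring carbon is drawn S in compound 2 and R in compound 3; a stereocentre at a saturated ring carbon is drawn S in compound 2 and R in compound 3 and no measured step tests such a difference in configuration. Among the compounds with values here, the sole guide is a 1.1-fold lower number from compound 1 to compound 2 (0.03 log units; within the scatter) which lies within the scatter and concerns hydroxy in place of hydrogen on a saturated ring carbon. The expected size is a 1.2-fold higher number from compound 2 to compound 3 (0.07 log units; within the scatter) and no change beyond the scatter is expected. For compound 3 the estimate is 23000 nM with an expected range of 9000 nM to 60000 nM as a working figure.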

Compound 3, half-maximal inhibitory concentration: 5100 nM
The estimate for compound 3 lay 4.5-fold (0.65 log units) above the measured number, outside the stated range (below it).
By their numbers in this assay, from the lowest: compound 3; then compounds 2 and 1 (each within the scatter of the next).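

In this assay, the hydroxy on the saturated ring carbon had first shifted nothing beyond the scatter, whereas the new result is a 3.9-fold lower number from compound 2 to compound 3 (0.59 log units; beyond the scatter). Against the parent without the hydroxy, the drawn R,R arrangement gives a 4.1-fold lower number from compound 1 to compound 3 (0.61 log units; beyond the scatter), the first step in the series beyond the scatter. The change in the number is tied to stereochemistry alone: the fact that compounds 2 and 3 differ only in the configuration as drawn

Which of the two inverted stereocentres accounts for the step stays open. Also open, on these data alone, is whether a methoxy or an amine on that ring carbon would follow the hydroxy.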